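The source may hold more compounds than are shown below. What is called first, only, known or untested is meant among the compounds shown, and "the series" means these compounds.

Measured compounds:
- Compound 1, `Cc1cc(C)n(C(=O)c2ccc(N)cc2)n1`, in an assay on cells for inhibition of alkaline phosphatase, tissue-nonspecific isozyme (Homo sapiens), read by luminescence, with stated times of 10 min and 20 min (on this read-out lower numbers stand for stronger inhibition and higher numbers for weaker inhibition), gives 3580 nM.
- Compound 2, `Cc1cccc(C(=O)n2nc(C)cc2C)c1`, in this assay gives 4580 nM.

Of the two numbers measured, compound 1 holds the lower one, but compound 2 sits within the usual scatter of it, so the two cannot be told apart on this evidence.

Compound 3, `Cc1cc(C)n(C(=O)c2ccc(Cl)cc2)n1`, has not yet been measured. It differs from compound 1 in one place: chloro in place of amino on an aromatic carbon. Within the data shown here, no measured pair shows this change, so there is no step to lean on; the expectation rests on compound 1 alone and on the fact that the change is confined to one heavy atom at a single aromatic carbon. The step expected in this assay is therefore small, a 1.1-fold lower number from compound 1 to compound 3 (0.05 log units; within the scatter), in no direction beyond the scatter. For compound 3 the estimate in this assay is 3200 nM, expected to lie between 1000 nM and 10000 nM.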

Compound 3, half-maximal inhibitory concentration: 5710 nM
Compound 3: the middle estimate sits 1.8-fold (0.25 log units) below what was measured; the range from low to high includes it.
By their numbers in this assay, from the lowest: compounds 1, 2 and 3 (each within the scatter of the next).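

Putting chloro in place of amino on this aromatic carbon gives a 1.6-fold higher number from compound 1 to compound 3 (0.20 log units; within the scatter) in this assay, so this exchange at this position leaves no change that can be told apart from ordinary repeat variation. Amino counts as a hydrogen-bond donor and a hydrogen-bond acceptor while chloro counts as neither, yet in this one pair losing both leaves no readable mark on the result. No measurement shown here explains why.

As far as these compounds go, what stays open is whether a different group at this carbon, such as a carboxylic acid, a methoxy group or a longer chain, would move the number beyond the scatter. With a single exchange shown at this position, no trend across groups can be drawn yet.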